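A Trifluoromethyl Variant in a Series Held at the Limit

This account rests on a few compounds, and the source may have more. Where it says the series, first, only, none or still open, it means among the compounds named here.

Compound 3 `C=C1C[C@]23C[C@@]1(O)CC[C@@H]2c1cccc(C)c1[C@@H]3Cn1cc(-c2ccc(F)cc2)nn1` carries a 4-fluorophenyl group on an aromatic carbon of the shared core. In a functional assay on SMMC-7721 cells (Homo sapiens) for cytotoxicity, read by MTT assay, with a stated time of 4 days (on this read-out lower numbers stand for stronger inhibition and higher numbers for weaker inhibition), compound 3 gives > 20000 nM, which is a limit of the assay and not a number. Compound 1 `C=C1C[C@]23C[C@@]1(O)CC[C@@H]2c1cccc(C)c1[C@@H]3Cn1cc(-c2ccc(Cl)cc2)nn1` bears 4-chlorophenyl at the same place, and in this assay compound 1 gives > 20000 nM, again a limit. Compound 2 `C=C1C[C@]23C[C@@]1(O)CC[C@@H]2c1cccc(C)c1[C@@H]3Cn1cc(-c2ccccn2)nn1` has pyridin-2-yl there, and in this assay compound 2 gives > 20000 nM, also a limit. Because all three values sit at the limit of > 20000 nM in this assay, at which 3 of the 3 values shown sit, none of the steps between them can be sized: a step that the two limits leave unreadable from compound 1 to compound 2, a step that the two limits leave unreadable from compound 1 to compound 3 and a step that the two limits leave unreadable from compound 2 to compound 3 all stay unreadable. Compound 3 therefore stands level with the other two, at the limit rather than at a number. Compound 4 `C=C1C[C@]23C[C@@]1(O)CC[C@@H]2c1cccc(C)c1[C@@H]3Cn1cc(-c2ccc(C(F)(F)F)cc2)nn1` differs from compound 3 by trifluoromethyl in place of fluoro on an aromatic carbon. Each of the measured steps changed only the group at this place and left the value at the limit, so no step beyond the scatter is expected from this change either. For compound 4 a value of 30000 nM is estimated, within 10000 nM to 100000 nM, most likely reported again as a limit. For compound 4 the expected step is a step that the limit leaves unreadable from compound 3 to compound 4.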

Compound 4, half-maximal inhibitory concentration: > 20000 nM
Compound 4: no number, only a limit (the forecaster's own chance of this, stated with the estimate: 80%); the middle value is on the limit's open side.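

Compound 4 also ends at a limit of the assay and not at a number, so the steps linking it with compound 1, compound 2 and compound 3 cannot be read: the limit of > 20000 nM in this assay, at which 4 of the 4 values shown sit. The compounds shown leave open how far each one lies past the limit in this assay, and whether any group at this place gives a readable value.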